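Thiazolyl for phenyl in a histamine H2 agonist series

The source may hold more compounds than are shown below. What is called first, only, known or untested is meant among the compounds shown, and "the series" means these compounds.

Three measured compounds share a common core. In a functional assay on cardiac atrium for agonist activity at histamine H2 receptor (Cavia porcellus) (a higher number here means that more compound is needed for the effect, a lower number that less compound is needed), compound 1 `N=C(NCCCc1c[nH]cn1)NCCC(c1ccc(F)cc1)c1ccccn1` gives 9.77 nM. Compound 2 `N=C(NCCCc1c[nH]cn1)NC(=O)CC(c1ccccc1)c1ccccc1` gives 28.2 nM in this assay, the second highest of the three numbers; its gap to compound 1 lies beyond the scatter, as does the far larger gap to compound 3 `N=C(NCCCc1c[nH]cn1)NC(=O)C(c1ccccc1)c1ccccc1`, which gives 1050 nM in this assay. Compound 4 `N=C(NCCCc1c[nH]cn1)NC(=O)CC(c1ccccc1)c1nccs1` has not yet been measured. It differs from compound 2 by 1,3-thiazol-2-yl in place of phenyl on a saturated chain carbon bound to an aromatic carbon and a saturated chain carbon. Going by the values given here, no step between two measured compounds matches this change, so the expectation rests on compound 2 alone. The step is expected to be small, a 1.4-fold lower number from compound 2 to compound 4 (0.15 log units; within the scatter), possibly within the scatter in either direction. Compound 4 is estimated at 20 nM, with a range from 6 nM to 70 nM.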

Compound 4, half-maximal effective concentration: 38 nM
Compound 4: middle estimate off by 1.9-fold (0.28 log units), on the low side; the range from low to high includes it.
By their numbers in this assay, from the lowest: compound 1; then compounds 2 and 4 (each within the scatter of the next); then compound 3.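

In this assay the exchange of phenyl for 1,3-thiazol-2-yl on a saturated chain carbon bound to an aromatic carbon and a saturated chain carbon gives a 1.3-fold higher number from compound 2 to compound 4 (0.13 log units; within the scatter) for this pair. Going by these compounds alone, this is the first step read at this position, and it shows that a five-membered aromatic ring with 2 hetero atoms can stand there in place of one phenyl without a change beyond the scatter. Nothing at hand explains this result. Going by these compounds, whether an oxazol-2-yl ring or a carboxylic acid in the same place would also stay within the scatter of compound 2 remains open. So does the effect of replacing the remaining phenyl of compound 4 with a second 1,3-thiazol-2-yl.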